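The compounds below may be only part of what the source reports. "The series", "measured", "known", "first", "only" and "open" are said of these compounds alone.

Compound 1 `CCn1c(/C=C2/C(=O)Nc3ccc(F)cc32)nc2ccccc21` gives > 50000 nM in a functional assay on MCF7 cells (Homo sapiens) for cytotoxicity, read by MTT assay, with a stated time of 48 h (a higher number here means a weaker inhibitor, a lower number a stronger inhibitor), which is a limit of the assay and not a number.
Compound 2 `Cn1c(/C=C2/C(=O)Nc3ccc(F)cc32)nc2ccccc21` gives 31600 nM in this assay.
Compound 3 `Cn1c(/C=C2/C(=O)Nc3ccc(Cl)cc32)nc2ccccc21` gives > 50000 nM in this assay, again a limit of the assay rather than a number.

The three measured compounds share one core and are varied at two places. Only compound 2 returns a number; the other two sit at the limit of > 50000 nM in this assay, at which 2 of the 3 values shown sit. From compound 2 to compound 1 the change is methyl in place of hydrogen on a saturated chain carbon bound to an aromatic nitrogen, and an at least 1.5-fold higher number from compound 2 to compound 1 (0.19 log units; that floor lies within the scatter). From compound 2 to compound 3 the change is chloro in place of fluoro on an aromatic carbon, and an at least 1.5-fold higher number from compound 2 to compound 3 (0.19 log units; that floor lies within the scatter). In both cases the measured value moves from a number to a limit, so the true size of either step is not known beyond its floor.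

Compound 4 `CCn1c(/C=C2/C(=O)Nc3ccc(Cl)cc32)nc2ccccc21` has not yet been measured in this assay. It differs from compound 3 by methyl in place of hydrogen on a saturated chain carbon bound to an aromatic nitrogen, the same change that was made from compound 2 to compound 1, at a place described in identical words. Compound 4 combines the two features that each, on its own, carried a compound from a number to the limit. It is therefore expected to give a limit as well. The step from compound 3 is estimated as a step that the limit leaves unreadable from compound 3 to compound 4, though with compound 3 already at a limit, this rests on weak ground. Compound 4 is estimated at 80000 nM, with a range from 40000 nM to 200000 nM.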

Compound 4, half-maximal inhibitory concentration: > 50000 nM
Compound 4: no number, only a limit; the forecaster's own chance of this, stated with the estimate: 85%; the middle value lies beyond the limit too.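

Compound 4 also ends at a limit of the assay in this assay, so its steps from compound 3 and from compound 1 cannot be read, as those two compounds stand at the same limit: the limit of > 50000 nM in this assay, at which 3 of the 4 values shown sit.

The compounds shown leave open how far compound 1, compound 3 and compound 4 actually lie from compound 2, and whether the two changes add up when combined.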